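Solubility in a Nitroimidazole Series with Alkyne and Alkyl Linkers

This account rests on a few compounds, and the source may have more. Where it says the series, first, only, none or still open, it means among the compounds named here.

Of the compounds shown here, three have been measured in a physicochemical assay for solubility, read by HPLC, at pH 7; a higher number here means a more soluble compound, a lower number a less soluble compound. Compound 1 `O=[N+]([O-])c1cn2c(n1)OC[C@@H](OCC#Cc1ccc(OCc3ccccc3)cc1)C2` gives 0.43 ug/mL, compound 2 `O=[N+]([O-])c1cn2c(n1)OC[C@@H](OCC#Cc1ccc(-c3ccc(OC(F)(F)F)cc3)cc1)C2` gives 0.07 ug/mL, and compound 3 `O=[N+]([O-])c1cn2c(n1)OC[C@@H](OCCCc1ccc(-c3ccc(OC(F)(F)F)cc3)cc1)C2` gives 1.7 ug/mL, the highest of the three. Between compound 2 and compound 1 the change is benzyloxy in place of 4-(trifluoromethoxy)phenyl on an aromatic carbon, and in this assay it produces a 6.1-fold higher number from compound 2 to compound 1 (0.79 log units; beyond the scatter). Compound 4 `O=[N+]([O-])c1cn2c(n1)OC[C@@H](OCCCc1ccc(OCc3ccccc3)cc1)C2` is related to compound 3 by the same change, (benzyloxy in place of 4-(trifluoromethoxy)phenyl on an aromatic carbon); the difference between the cores of compound 2 and compound 3 is not broken down here. Among the compounds with values here, because the single earlier step of a 6.1-fold higher number from compound 2 to compound 1 (0.79 log units; beyond the scatter) was beyond the scatter, compound 4 is expected to show a comparable rise, a 4.7-fold higher number from compound 3 to compound 4 (0.67 log units; beyond the scatter), though this rests on one example only. In this assay compound 4 is therefore estimated at 8 ug/mL, most likely between 2.5 ug/mL and 25 ug/mL.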

Compound 4, solubility: 3.8 ug/mL
For compound 4 the middle estimate is 2.1-fold (0.32 log units) above the measured one; the range from low to high includes it.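

In this assay benzyloxy in place of 4-(trifluoromethoxy)phenyl again gives a rise on the second core, with a 2.2-fold higher number from compound 3 to compound 4 (0.35 log units; beyond the scatter) matching in direction the earlier 6.1-fold higher number from compound 2 to compound 1 (0.79 log units; beyond the scatter) and both steps lying beyond the scatter. Within the data shown here, this shows that the direction of the change carried across these two cores, but with only two pairs it does not show that the size of the step carries over, or that the direction would hold on any other core. No measurement shown accounts for the rise in either pair.

The compounds shown leave open how an amine or a carboxylic acid would read on that aromatic carbon. They also leave open whether the change would behave alike on a core with a longer chain.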